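The source may hold more compounds than are shown below. What is called first, only, known or untested is meant among the compounds shown, and "the series" means these compounds.

Measured compounds in a functional assay on HEL cells (Homo sapiens) for inhibition; a lower number here means that less compound is tolerated, a higher number that more compound is tolerated:
Compound 1 `C#CCOCN1c2ccccc2C(=O)N(Cc2ccccc2)S1(=O)=O` sits at a limit of the assay, > 140000 nM.
Compound 2 `O=C1c2ccccc2N(Cc2ccccc2Cl)S(=O)(=O)N1Cc1ccccc1` gives 88000 nM.
Compound 3 `O=C1c2ccccc2N(Cc2ccc(Cl)cc2)S(=O)(=O)N1Cc1ccc(Cl)cc1` sits at a limit of the assay, > 200000 nM.

Compound 3 thus stands at the limit of > 200000 nM in this assay, at which 1 of the 3 values shown sits, with no number of its own; compound 1 stands at the limit of > 140000 nM in this assay, at which 1 of the 3 values shown sits. Compound 4 `O=C1c2ccccc2N(Cc2ccc(Cl)cc2)S(=O)(=O)N1Cc1ccccc1` differs from compound 3 by hydrogen in place of chloro on an aromatic carbon, 4-chlorobenzyl to benzyl. Within the data shown here, the only measured step, an at least 1.5-fold lower number from compound 1 to compound 2 (0.20 log units; that floor lies within the scatter), concerns a different place and has a floor within the scatter, so it gives no direction for this change. Compound 2, which also carries one benzyl, gives 88000 nM, a number rather than a limit. For compound 4 the expected step is an at least 1.3-fold lower number from compound 3 to compound 4 (0.12 log units; that floor lies within the scatter), within the scatter. Compound 4 is estimated at 150000 nM, range 60000 nM to 250000 nM, with a fair chance of a limit only.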

Compound 4, half-maximal cytotoxic concentration: > 200000 nM
Compound 4: no number, only a limit; the forecaster's own chance of this, stated with the estimate: 50%; middle value at least 1.3-fold (0.12 log units) from the limit.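

In this assay, 4-chlorophenyl in place of 2-chlorophenyl on the saturated chain carbon bound to the ring sulfonamide nitrogen gives an at least 2.2-fold higher number from compound 2 to compound 4 (0.35 log units; beyond the scatter). Among these compounds, this is the first step beyond the scatter, and it shows that the place of the chloro on this phenyl ring counts in this assay. The steps to compound 4 from compound 1 and from compound 3 cannot be read, and compound 4 itself stands at a limit: the limit of > 200000 nM in this assay, at which 2 of the 4 values shown sit.

From the compounds shown here alone, the size of the change on removing chloro from compound 3 stays open. So does the effect of an amine or a carboxylic acid in place of chloro on this phenyl ring.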